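Removing Both Chlorines from the Aryl Piperazine

The compounds below may be only part of what the source reports. "The series", "measured", "known", "first", "only" and "open" are said of these compounds alone.

Within the data shown here, compound 3 `O=C1c2ccccc2S(=O)(=O)N1CCCCCCN1CCN(c2ccc(Cl)c(Cl)c2)CC1` gives 258 nM in an ADME assay on HEK293 cells for displacement of a labelled ligand from 5-hydroxytryptamine receptor 7 (Homo sapiens), read by radioligand binding, with a stated time of 1 h (a lower number here means a stronger inhibitor, a higher number a weaker inhibitor), the second highest of the three numbers measured so far. Compound 1 `O=C1c2ccccc2S(=O)(=O)N1CCCCCCN1CCN(c2ccccc2Cl)CC1` gives 120 nM, and compound 2 `O=C1c2ccccc2S(=O)(=O)N1CCCCCCN1CCN(c2ccccc2F)CC1` gives 322 nM; the step of a 2.2-fold higher number from compound 1 to compound 3 (0.33 log units; beyond the scatter) lies beyond the scatter, whereas a 1.2-fold lower number from compound 2 to compound 3 (0.10 log units; within the scatter) does not. The change that leads to compound 4 `O=C1c2ccccc2S(=O)(=O)N1CCCCCCN1CCN(c2ccccc2)CC1` is phenyl in place of 3,4-dichlorophenyl on an amine nitrogen in a ring. Among the measured compounds shown here, no measured step removes the halogens altogether; the nearest comparisons, a 2.7-fold higher number from compound 1 to compound 2 (0.43 log units; beyond the scatter) and a 2.2-fold higher number from compound 1 to compound 3 (0.33 log units; beyond the scatter), each shift the number only modestly when the halogen pattern on the aryl ring changes. Compound 4 is therefore expected to move by at most a modest step, a 1.2-fold higher number from compound 3 to compound 4 (0.07 log units; within the scatter). The estimate for compound 4 is 300 nM, within a range from 120 nM to 750 nM.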

Compound 4, inhibition constant: 192 nM
Compound 4: middle estimate off by 1.6-fold (0.19 log units), on the high side; measured number inside the range.
By their numbers in this assay, from the lowest: compounds 1, 4, 3 and 2 (each within the scatter of the next, the first and the last beyond it).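

In this assay, phenyl in place of the halogenated rings gives no step beyond the scatter: a 1.3-fold lower number from compound 3 to compound 4 (0.13 log units; within the scatter), a 1.7-fold lower number from compound 2 to compound 4 (0.22 log units; within the scatter) and a 1.6-fold higher number from compound 1 to compound 4 (0.20 log units; within the scatter). Removing the halogens altogether therefore leaves compound 4 within the scatter of all three halogenated compounds, so at this position no halogen is required for a number in this range. No supporting data explain this result. Still open, going by these compounds, is whether a methoxy group or a nitrile on the phenyl ring would move the number beyond the scatter, and whether a shorter chain would do so.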